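Dimethylamino in Place of Methoxy, Tested a Second Time

The source may hold more compounds than are shown below. What is called first, only, known or untested is meant among the compounds shown, and "the series" means these compounds.

Measured so far in a functional assay on HT-29 cells (Homo sapiens) for inhibition; a higher number here means a weaker inhibitor, a lower number a stronger inhibitor:
compound 1 `COc1ccc(/C=C/c2ccc3ccccc3c2)cc1`: > 5000 nM
compound 2 `CN(C)c1ccc(/C=C/c2ccc3ccccc3c2)cc1`: 3660 nM
compound 3 `COc1c([N+](=O)[O-])cc(/C=C/c2ccc3ccccc3c2)cc1[N+](=O)[O-]`: > 5000 nM

The value of compound 1 is a limit of the assay, not a number. The value of compound 3 is likewise a limit. Compound 2 carries the change (dimethylamino in place of methoxy on an aromatic carbon), and the measured step was an at least 1.3-fold lower number from compound 1 to compound 2 (0.13 log units; that floor lies within the scatter); both values that are limits sit at the limit of > 5000 nM in this assay, at which 2 of the 3 values shown sit.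

How the core of compound 1 and the core of compound 3 differ is not broken down here. Compound 4 `CN(C)c1c([N+](=O)[O-])cc(/C=C/c2ccc3ccccc3c2)cc1[N+](=O)[O-]` carries the same kind of change as compound 2, namely (dimethylamino in place of methoxy on an aromatic carbon), but here the place is ortho to two nitro groups (3 heavy atoms each), which is not the case in compound 2.

Since the earlier step from compound 1 to compound 2 began at a limit and reached only a small measured number, the step from compound 3 to compound 4 is expected to be of a similar small size, a step that the limit leaves unreadable from compound 3 to compound 4. Compound 4 is therefore estimated at 6000 nM, with a range from 2500 nM to 20000 nM, and a measurement reporting only a limit is quite possible.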

Compound 4, half-maximal inhibitory concentration: > 5000 nM
Compound 4 was reported as a limit (the forecaster's own chance of this, stated with the estimate: 55%); the middle value does not contradict the limit.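

In this assay compound 3 gives > 5000 nM, a limit and not a number. Compound 4 gives > 5000 nM, also a limit, so no step can be read between it and compound 3: the limit of > 5000 nM in this assay, at which 3 of the 4 values shown sit.

The compounds shown leave open whether dimethylamino in place of methoxy changes the number at all when ortho to two nitro groups.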